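Swapping nitro for methoxy in compound 1

The compounds below may be only part of what the source reports. "The series", "measured", "known", "first", "only" and "open" are said of these compounds alone.

Results in a functional assay on MT4 cells (Homo sapiens) for cytotoxicity, read by MTT assay (on this read-out higher numbers stand for lower toxicity in this test and lower numbers for higher toxicity in this test), are as follows
- compound 1 (`Cc1c(O)nc(S(=O)(=O)Cc2ccc([N+](=O)[O-])cc2)nc1Cc1c(Cl)cccc1Cl`) gives a limit, > 53000 nM
- compound 2 (`Cc1c(O)nc(SCc2ccc(Cl)cc2)nc1Cc1c(Cl)cccc1Cl`) gives a limit, > 59000 nM
- compound 3 (`Cc1c(O)nc(SCc2ccccc2)nc1Cc1c(Cl)cccc1Cl`) gives a limit, > 64000 nM
- compound 4 (`COc1ccc(CS(=O)(=O)c2nc(O)c(C)c(Cc3c(Cl)cccc3Cl)n2)cc1`) has not yet been measured

Compound 1 has no exact number in this assay, only a limit (> 53000 nM). Neither of the other two measured compounds offers an exact number to compare it with, since each of them also stops at a limit.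

Compound 4 differs from compound 1 in one place, with methoxy in place of nitro on an aromatic carbon, para to a large group (methoxy in place of nitro on an aromatic carbon). For the measured compounds named here, the only measured single change is a different one, with hydrogen in place of chloro on an aromatic carbon (a step that the two limits leave unreadable from compound 2 to compound 3). Its size cannot be read, so it gives no size to carry over to the new change.

All three measured compounds end at a limit, and none goes against that. Compound 4 is therefore expected to end at a limit too, with no step beyond the usual scatter. The expected change is small (a step that the limit leaves unreadable from compound 1 to compound 4). In this assay the estimated value for compound 4 is 55000 nM, with an expected range from 20000 nM to 110000 nM.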

Compound 4, half-maximal cytotoxic concentration: 2800 nM
Compound 4: the middle estimate sits 20-fold (1.29 log units) above what was measured; the measured number lies below the stated range.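

In this assay, for the compounds shown here, the change from 4-nitrobenzyl to 4-methoxybenzyl gives an at least 18-fold lower number from compound 1 to compound 4 (1.27 log units; beyond the scatter), the first step in this set whose size can be read, and the lower number stands for higher toxicity in this test. The earlier compounds shown here could not show this: all three end at limits, so the step between compound 2 and compound 3 cannot be read, and nothing showed that this aromatic carbon, para to a large group, could matter here. The printed size is only a minimum, because compound 1 has no exact number and ends at a limit: the limit of > 53000 nM in this assay, at which 1 of the 4 values shown sits.

As far as these compounds go, with a single readable step, it remains open whether the higher toxicity of compound 4 goes with the arrival of methoxy or the departure of nitro, and a compound with hydrogen or an amine at the same carbon would help separate the two. From the compounds shown here alone, it is also open whether methoxy would produce a similar step on the thioether form of the molecule, as a methoxy partner of compound 3 would show.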